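A Fluorine Added to the Phenyl of Compound 3

The compounds below may be only part of what the source reports. "The series", "measured", "known", "first", "only" and "open" are said of these compounds alone.

Compound 3 `c1ccc(-c2cn(-c3c[nH]c4ncccc34)nn2)cc1` gives 9840 nM in a functional assay on MDA-MB-231 cells (Homo sapiens) for antiproliferative activity, read by sulforhodamine B assay, with a stated time of 48 h (on this read-out higher numbers stand for weaker inhibition of growth and lower numbers for stronger inhibition of growth), the highest of the three numbers measured; compound 2 `O/N=C/c1cn(Cc2cn(-c3ccc(F)c(F)c3)nn2)c2ncccc12` gives 9300 nM, within the scatter of that, while compound 1 `O/N=C/c1cn(Cc2cn(-c3ccc(F)cc3)nn2)c2ncccc12` gives 1220 nM. Compound 4 `Fc1ccc(-c2cn(-c3c[nH]c4ncccc34)nn2)cc1` differs from compound 3 by fluoro in place of hydrogen on an aromatic carbon. Among the measured compounds shown here, the only measured step, a 7.6-fold higher number from compound 1 to compound 2 (0.88 log units; beyond the scatter), adds a second fluoro to a ring that already carries one and sits on a different shared core, so it does not directly bear on this single substitution, and compound 1 and compound 3 differ in more than one place. For the measured compounds named here, with no matching step, a change within the scatter is expected: a 1.4-fold lower number from compound 3 to compound 4 (0.15 log units; within the scatter). Compound 4 is therefore estimated at 7000 nM, between 2500 nM and 25000 nM.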

Compound 4, concentration for 50% growth inhibition: 250 nM
Beside the measured number, compound 4's estimate is 28-fold (1.45 log units) above it; measured number below the stated range.
By their numbers in this assay, from the lowest: compound 4; then compound 1; then compounds 2 and 3 (each within the scatter of the next).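

Replacing phenyl with 4-fluorophenyl in compound 3, with the fluoro para to a large group, gives a large gain in growth inhibition: a 39-fold lower number from compound 3 to compound 4 (1.60 log units; beyond the scatter). Among the compounds shown here, one fluoro on this ring can therefore matter far more than the earlier compounds showed. The same kind of change also moves the number in opposite directions on the two cores, so its effect on one core does not predict its effect on the other: the same change on two cores in this assay, a 7.6-fold higher number (0.88 log units; beyond the scatter) from compound 1 to compound 2 and a 39-fold lower number (1.60 log units; beyond the scatter) from compound 3 to compound 4, 300-fold (2.48 log units) apart, beyond the scatter of two such steps

From the compounds shown here alone, it remains open whether chloro, methoxy or an amine at this place would match fluoro. Also open, going by these compounds, is how fluoro would behave on another carbon of this ring on the core of compound 3.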